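A Bulkier Chain Replaces the Small Ring

A few compounds are considered here, and "the series" means these few. Any claim that something is new, unique, unknown or untested is made for them only; others in the source may bear on it.

In an in vitro functional assay on cells for agonist activity at Bombesin receptor subtype-3 (Homo sapiens), read by luminescence and calcium flux (on this read-out lower numbers stand for an effect already at smaller amounts and higher numbers for an effect only at larger amounts of compound), compound 2 `O=C(O)c1ccccc1-c1ccc(CCc2ncc(CC3CCC3)[nH]2)cc1` gives 588 nM, the lowest of the two numbers recorded so far; compound 1 `CCCCc1cnc(C(CCCO)Cc2ccc(-c3ccccc3C(=O)O)cc2)[nH]1` gives 1900 nM, a gap beyond the usual scatter. Compound 3 `CC(C)(C)CCc1cnc(CCc2ccc(-c3ccccc3C(=O)O)cc2)[nH]1` awaits measurement and differs from compound 2 by neopentyl in place of cyclobutyl on a saturated chain carbon bound to an aromatic carbon. Going by the values given here, no step between two measured compounds isolates a change of this kind, so its weight is unknown. In this assay a step of about a 1.1-fold lower number from compound 2 to compound 3 (0.03 log units; within the scatter) is expected, none beyond the scatter in either direction. Compound 3 is accordingly estimated at 550 nM, within a range from 180 nM to 1800 nM.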

Compound 3, half-maximal effective concentration: 39 nM
Estimate against measurement, compound 3: 14-fold (1.15 log units) above, and the stated range ends above it.
By their numbers in this assay, from the lowest: compound 3; then compound 2; then compound 1.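

In this assay the change runs a 15-fold lower number from compound 2 to compound 3 (1.18 log units; beyond the scatter) and shows that this position, on a saturated chain carbon bound to an aromatic carbon, responds strongly to which carbon-only group it carries. Cyclobutyl and neopentyl alike have no hydrogen-bond donors, acceptors or net charge, so the large step accompanies a change in the carbon framework alone. Nothing measured here explains it. The compounds shown leave open whether a longer unbranched chain or a cyclohexyl ring at this place would match neopentyl.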